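The source may report more compounds than this note shows. Statements on the series, on what has been measured and on what is new or still open speak of the compounds shown alone.

In a functional assay on BT-474 cells (Homo sapiens) for inhibition, read by fluorescence, with a stated time of 72 h (a higher number here means a weaker inhibitor of growth, a lower number a stronger inhibitor of growth), compound 1 (`N[C@H]1CC[C@H](Nc2nc(Nc3ccc(O)cc3)c3ncn(C4CCCCC4)c3n2)CC1`) gives 27300 nM, and compound 2 (`CC(C)CCn1cnc2c(Nc3ccccc3)nc(N[C@H]3CC[C@H](N)CC3)nc21`) gives 6400 nM, the lower of the two numbers and beyond the scatter of compound 1. Compound 3 (`CC(C)CCn1cnc2c(Nc3ccc(O)cc3)nc(N[C@H]3CC[C@H](N)CC3)nc21`) departs from compound 2 by a single change: hydroxy in place of hydrogen on an aromatic carbon. Among the compounds with values here, no measured pair isolates this change. Compound 1, at 27300 nM, carries the same 4-hydroxyphenyl group but also differs elsewhere, so only a slight upward shift, within the scatter, is expected. The estimated change is a 1.2-fold higher number from compound 2 to compound 3 (0.07 log units; within the scatter). For compound 3 the expected value is 7500 nM, with an estimated range of 2200 nM to 25000 nM.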

Compound 3, concentration for 50% growth inhibition: 7700 nM
Compound 3: the middle estimate sits 1.0-fold (0.01 log units) below what was measured; low and high end bracket the measured number.
By their numbers in this assay, from the lowest: compounds 2 and 3 (each within the scatter of the next); then compound 1.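

In this assay, phenyl to 4-hydroxyphenyl now has a direct pair, a 1.2-fold higher number from compound 2 to compound 3 (0.08 log units; within the scatter), so hydroxy in place of hydrogen para to a large group leaves the number within the scatter. Within the data shown here, with 4-hydroxyphenyl held constant, isopentyl in place of cyclohexyl on the aromatic nitrogen gives a 3.5-fold lower number from compound 1 to compound 3 (0.55 log units; beyond the scatter), a first reading of that position. Nothing on hand accounts for either step.

Still open, as far as these compounds go, is whether an amine or a carboxylic acid at the same para place would also stay within the scatter. Also open, from the compounds shown here alone, is whether a longer chain on the aromatic nitrogen would extend the step seen with isopentyl.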